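Swapping the Methoxythiophene for an Ethylthiophene in Sulfonylureas

A few compounds are considered here, and "the series" means these few. Any claim that something is new, unique, unknown or untested is made for them only; others in the source may bear on it.

Compound 1, `Cc1ccc(S(=O)(=O)NC(=O)Nc2ccc(Cl)c(Cl)c2)s1`, gives 61% in a functional assay on the whole organism (6C3HED cells, Mus musculus) for inhibition, at a dose of 300 mg/kg by the oral route; on this read-out lower numbers stand for less inhibition and higher numbers for more inhibition at the one dose given (going by the name of the read-out). Compound 2, `COc1ccc(S(=O)(=O)NC(=O)Nc2ccc(Cl)cc2)s1`, gives 100%. Compound 3, `CCCc1ccc(S(=O)(=O)NC(=O)Nc2ccc(Cl)cc2)s1`, gives 39%.

Compound 2 stands highest of the three in this assay; compound 1 lies well below it and compound 3 lower still, both gaps beyond the scatter. Compound 4, `CCc1csc(S(=O)(=O)NC(=O)Nc2ccc(Cl)cc2)c1`, is not yet measured. It differs from compound 2 by a group of 7 heavy atoms (6 carbon, 1 sulfur; one five-membered aromatic ring with 1 hetero atom) in place of a group of 7 heavy atoms (5 carbon, 1 oxygen, 1 sulfur; one five-membered aromatic ring with 1 hetero atom), on a sulfonyl sulfur. Going by the values given here, one measured step bears on this exchange of an oxygen-bearing ring for a purely carbon-substituted one: a number 61 percentage points lower from compound 2 to compound 3 (beyond the scatter). On that basis a downward step is expected, a number 45 percentage points lower from compound 2 to compound 4 (beyond the scatter), though the different placement of the alkyl group leaves room for a smaller loss. Compound 4 is therefore estimated at 55%, within 30% to 85%.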

Compound 4, a percentage reported as inhibition, in the whole organism at one dose (the size of the read-out at that dose, not a potency): 93%
For compound 4 the middle estimate is 38 percentage points below the measured one; measured number outside the range, above it.
By their numbers in this assay, from the lowest: compound 3; then compound 1; then compounds 4 and 2 (each within the scatter of the next).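

In this assay, the exchange on the sulfonyl sulfur gives a number 7 percentage points lower from compound 2 to compound 4 (within the scatter), so the oxygen of the 5-methoxythiophen-2-yl group is not required for a high number at this place. The earlier step, a number 61 percentage points lower from compound 2 to compound 3 (beyond the scatter), therefore does not hold for every replacement without oxygen. Nothing measured here explains the difference between these two replacements.

Going by these compounds, it remains open whether an amine or a carboxylic acid on this ring would keep the number high. Also open, on these data alone, is whether the same exchange would hold on the core of compound 1.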